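A few compounds are considered here, and "the series" means these few. Any claim that something is new, unique, unknown or untested is made for them only; others in the source may bear on it.

Compound 1 `CCN(CC)CN1C(=O)/C(=N/NC(=S)Nc2ccc(Cl)cc2)c2ccccc21`: 800 nM
Compound 2 `CCN(CC)CN1C(=O)/C(=N/NC(N)=S)c2cc(Cl)ccc21`: 100000 nM
Compound 3 `CCN(CC)CN1C(=O)/C(=N/NC(=S)Nc2ccccc2)c2ccccc21`: 800 nM

These three compounds share one core and were all tested in an ADME assay on MDCK cells (Canis lupus familiaris) for cytotoxicity; a higher number here means that more compound is tolerated, a lower number that less compound is tolerated. Compound 2 stands highest of the three, and its gap to compound 1 and to compound 3 lies beyond the scatter of the measurement, while compound 1 and compound 3 give the same number within that scatter. Compound 2 differs from the other two in that the nitrogen next to its thiocarbonyl carbon carries only hydrogens, whereas in compound 1 and compound 3 that nitrogen carries an aromatic ring. Among the compounds with values here, the single measured step, no change at the digits printed from compound 1 to compound 3 (within the scatter), shows that exchanging chloro for hydrogen on an aromatic carbon of that ring leaves the number where it was.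

Compound 4 `CCN(CC)CN1C(=O)/C(=N/NC(=S)Nc2ccc(OC)cc2)c2cc(Cl)ccc21` is built from compound 2 by the change (4-methoxyphenyl in place of hydrogen on an amide-type nitrogen). Within the data shown here, no measured step covers this exact change. What the values show is that the two compounds carrying an aromatic ring on that nitrogen, compound 1 and compound 3, sit far below compound 2, and that the substitution on that ring did not matter from compound 1 to compound 3. A large drop in this assay is therefore expected, a 100-fold lower number from compound 2 to compound 4 (2.00 log units; beyond the scatter), bringing compound 4 close to the level of compound 1 and compound 3. Compound 4 is estimated at 1000 nM, within a range from 300 nM to 5000 nM.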

Compound 4, minimum cytotoxic concentration: >= 800 nM
Compound 4 was reported as a limit; the forecaster's own chance of this, stated with the estimate: 5%; the middle value does not contradict the limit.
By their numbers in this assay, from the lowest: compounds 1 and 3 (each within the scatter of the next); then compound 2.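

In this assay, compound 4 is reported only as a limit, >= 800 nM. The step from compound 2 to compound 4 cannot be read from this, so the result gives no new comparison. The compounds shown leave open the actual number for compound 4, and with it how much 4-methoxyphenyl in place of hydrogen on the amide-type nitrogen changes the number of compound 2.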